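The source may report more compounds than this note shows. Statements on the series, on what has been measured and on what is new or still open speak of the compounds shown alone.

Working notes on a short series sharing one core. Compound 1 `Fc1ccc(-c2ccc(-c3ccc(-c4nc5ccccc5[nH]4)cc3)cc2)cc1` gives 41300 nM in a functional assay on KB cells (Homo sapiens) for inhibition, read by sulforhodamine B assay; a lower number here means a stronger inhibitor of growth, a higher number a weaker inhibitor of growth. Compound 2 `FC(F)(F)c1ccc(-c2ccc(-c3ccc(-c4nc5ccccc5[nH]4)cc3)cc2)cc1` carries the change (trifluoromethyl in place of fluoro on an aromatic carbon); this gave a 1.1-fold higher number from compound 1 to compound 2 (0.06 log units; within the scatter), and compound 2 gives 47200 nM. Compound 3 `Cc1ccc2[nH]c(-c3ccc(-c4ccc(-c5ccc(F)cc5)cc4)cc3)nc2c1` differs from compound 1 in the core by methyl in place of hydrogen on an aromatic carbon; this gave a 1.7-fold lower number from compound 1 to compound 3 (0.22 log units; within the scatter), and compound 3 gives 24900 nM. All three numbers sit within the scatter of one another, so no order among them is claimed.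

Compound 4 `Cc1ccc2[nH]c(-c3ccc(-c4ccc(-c5ccc(C(F)(F)F)cc5)cc4)cc3)nc2c1` is not yet measured. It relates to compound 3 as compound 2 relates to compound 1, by the change (trifluoromethyl in place of fluoro on an aromatic carbon), at a place described in the same words both times, so it is the same change. Among the measured compounds shown here, the only guide is the one earlier case, where the change gave a 1.1-fold higher number from compound 1 to compound 2 (0.06 log units; within the scatter). On that basis the step is expected to be a 1.1-fold higher number from compound 3 to compound 4 (0.05 log units; within the scatter), because the earlier step of a 1.1-fold higher number from compound 1 to compound 2 (0.06 log units; within the scatter) lay within the scatter. Compound 4 is therefore estimated at 28000 nM in this assay, with a range from 14000 nM to 56000 nM.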

Compound 4, concentration for 50% growth inhibition: 41200 nM
Estimate against measurement, compound 4: 1.5-fold (0.17 log units) below; measured number inside the range.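

In this assay the exchange of fluoro for trifluoromethyl now reads as a 1.7-fold higher number from compound 3 to compound 4 (0.22 log units; within the scatter), and the two cores give the same answer for it within the scatter: the same change on two cores in this assay, a 1.1-fold higher number (0.06 log units; within the scatter) from compound 1 to compound 2 and a 1.7-fold higher number (0.22 log units; within the scatter) from compound 3 to compound 4, 1.4-fold (0.16 log units) apart, within the scatter of two such steps. The exchange of hydrogen for methyl on the core reads as a 1.1-fold lower number from compound 2 to compound 4 (0.06 log units; within the scatter), and it too gives the same answer on both partners: the same change on two cores in this assay, a 1.7-fold lower number (0.22 log units; within the scatter) from compound 1 to compound 3 and a 1.1-fold lower number (0.06 log units; within the scatter) from compound 2 to compound 4, 1.4-fold (0.16 log units) apart, within the scatter of two such steps. This shows that, across these four compounds, neither change has a measurable effect on either core, but with every step inside the scatter it does not show that a step of real size would carry from one core to another, and two cores are a thin basis for any rule.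

Still open, as far as these compounds go, is whether a different kind of group on that aromatic carbon, such as an amine, a carboxylic acid or a longer chain, would give a step beyond the scatter. Also open, from the compounds shown here alone, is whether a group other than methyl on the core, such as a nitrile or a carboxylic acid, would move the number, and whether such a step would then hold on both cores.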